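The source may hold more compounds than are shown below. What is called first, only, known or untested is meant among the compounds shown, and "the series" means these compounds.

Working notes on the series in an assay on COS-7 cells for inhibition of sodium/nucleoside cotransporter 2 (Homo sapiens), read by scintillation counting, in the presence of a further agent that is not named here; on this read-out higher numbers stand for weaker inhibition and lower numbers for stronger inhibition. Compound 1 `Nc1ncnc2c1ncn2[C@@H]1O[C@H](COC(=O)OCc2ccccc2)[C@@H](O)[C@H]1O` gives > 100000 nM, which is a limit of the assay and not a number. Compound 2 `CCOC(=O)OC[C@H]1O[C@@H](n2cnc3c(N)ncnc32)[C@H](O)[C@@H]1O` likewise gives > 100000 nM, again a limit of the assay. The step that the two limits leave unreadable from compound 1 to compound 2 therefore cannot be read. For the measured compounds named here, compound 3 `Nc1ncnc2c1nc(NCc1cccc(Cl)c1)n2[C@@H]1O[C@H](CO)[C@@H](O)[C@H]1O` gives 5400 nM, the only number in the set. The other two compounds sit at the limit of > 100000 nM in this assay, at which 2 of the 3 values shown sit. Compound 4 `Cc1cccc(CNc2nc3c(N)ncnc3n2[C@@H]2O[C@H](CO)[C@@H](O)[C@H]2O)c1` is not yet measured; it differs from compound 3 by methyl in place of chloro on an aromatic carbon. Going by the values given here, no measured step touches the (3-chlorobenzyl)amino group, and the one step measured is unreadable from its two limits, so the data give no direction for this change. The step of no change at the digits printed from compound 3 to compound 4 (within the scatter) is expected to stay within the scatter. Compound 4 is estimated at 5400 nM, with a range from 1800 nM to 16000 nM.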

Compound 4, half-maximal inhibitory concentration: 19000 nM
Compound 4: middle estimate off by 3.5-fold (0.55 log units), on the low side, outside the stated range (above it).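

In this assay, for the compounds shown here, the aromatic carbon meta to a large group is the first place where a change can be read: methyl in place of chloro gives a 3.5-fold higher number from compound 3 to compound 4 (0.55 log units; beyond the scatter). The (3-chlorobenzyl)amino group is therefore not indifferent to this swap, and chloro gives the stronger inhibition of the pair. No measurement shown gives a cause for this step.

Going by these compounds, whether fluoro, bromo, methoxy or trifluoromethyl on this carbon would give stronger or weaker inhibition than chloro stays open. So does whether the same swap has a similar effect elsewhere on the ring.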